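The source may report more compounds than this note shows. Statements on the series, on what has been measured and on what is new or still open speak of the compounds shown alone.

Notes on the series, cytotoxicity. The common core is the pyrimidine carrying the nitrile-bearing anilino group; compound 1 `N#Cc1ccc(Nc2nccc(SC3CCCCC3)n2)cc1` bears a cyclohexylsulfanyl group and no methyl. In an ADME assay on MT4 cells (Homo sapiens) for cytotoxicity, read by MTT assay (a lower number here means that less compound is tolerated, a higher number that more compound is tolerated), compound 1 gives only a limit, > 402000 nM, which is the assay's ceiling and not a number (the limit of > 402000 nM in this assay, at which 1 of the 3 values shown sits). Among the measured compounds shown here, compound 2 `Cc1cnc(Nc2ccc(C#N)cc2)nc1SC1CCCCC1` adds a methyl and in this assay gives 33400 nM; the step of an at least 12-fold lower number from compound 1 to compound 2 (1.08 log units; beyond the scatter) is the one measured change in the set. Compound 3 `Cc1cc(OC2CCCCC2)nc(Nc2ccc(C#N)cc2)n1`, with a cyclohexyloxy group and the methyl placed differently, gives 320 nM in this assay, the lowest number of the two full values; compound 2 therefore stands highest among the measured numbers. Compound 1, as said, sits at a limit.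

Compound 4 `Cc1cnc(Nc2ccc(C#N)cc2)nc1NC1CCCC1` is the next member: cyclopentylamino in place of cyclohexylsulfanyl on an aromatic carbon. For the measured compounds named here, no measured step bears on this change directly; the single measured step, an at least 12-fold lower number from compound 1 to compound 2 (1.08 log units; beyond the scatter), concerns the methyl, and the pair compound 2 to compound 3 differs in two places at once. The expectation for compound 4 in this assay is therefore wide, centred near no change beyond the scatter: the step is estimated at a 1.7-fold lower number from compound 2 to compound 4 (0.22 log units; within the scatter). Compound 4 is estimated at 20000 nM, with a range from 4000 nM to 120000 nM.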

Compound 4, half-maximal cytotoxic concentration: 170 nM
Compound 4: middle estimate off by 120-fold (2.07 log units), on the high side, outside the stated range (below it).
By their numbers in this assay, from the lowest: compounds 4 and 3 (each within the scatter of the next); then compound 2. At a limit, above all of these: compound 1.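

With the methyl held in place, cyclopentylamino in place of cyclohexylsulfanyl on this aromatic carbon, ortho to a methyl group, gives a 200-fold lower number from compound 2 to compound 4 (2.29 log units; beyond the scatter) in this assay, so the group at this position can by itself move the number by a large step. Among the compounds shown here, the only earlier step, an at least 12-fold lower number from compound 1 to compound 2 (1.08 log units; beyond the scatter), concerned the methyl, and this is the first measured step for a change of the group at this position. The change is not a single variable, as sulfur gives way to nitrogen, the six-membered ring gives way to a five-membered ring, and a hydrogen-bond donor enters, all in the same step, so the compounds shown cannot assign the step to any one of these.

Nothing measured here accounts for the size of this step. The compounds shown leave open whether the linking atom or the ring carries the step, which cyclohexylamino and cyclopentylsulfanyl at this position would separate, and how an open-chain group such as a longer alkylamino chain would read.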